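A few compounds are considered here, and "the series" means these few. Any claim that something is new, unique, unknown or untested is made for them only; others in the source may bear on it.

Compound 1, `O=C(CN(c1nc(Cl)nc2[nH]cnc12)C1CC1)N[C@@H](CO)C(=O)OCc1ccccc1`, in a functional assay on the whole organism (Tail, strain ICR) with Mus musculus as the target, in the tail flick test, with a stated time of 150 min, at a dose of 25 umol/kg by the oral route (a higher number here means a stronger effect of the compound at the dose given, a lower number a weaker effect), gives 27.9%.
Compound 2, `C[C@@H](O)[C@H](NC(=O)CN(c1nc(Cl)nc2[nH]cnc12)C1CC1)C(=O)OCc1ccccc1`, gives 12.8%.
Compound 3, `O=C(CN(c1nc(Cl)nc2[nH]cnc12)C1CC1)N[C@@H](CO)C(=O)O`, gives 18.8%.

Compound 3 stands second highest of the three numbers in this assay. Its nearest neighbour is compound 2, which lies within the scatter of it, and its furthest is compound 1, which is also within the scatter, so no order among these three is secure on these figures alone.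

The step considered here leads to compound 4, `C[C@@H](O)[C@H](NC(=O)CN(c1nc(Cl)nc2[nH]cnc12)C1CC1)C(=O)O`, not yet measured in this assay. Compound 4 differs from compound 3 as follows: methyl in place of hydrogen on a saturated chain carbon bound to an oxygen on a saturated carbon and a saturated chain carbon.

Within the data shown here, one measured step bears directly on this change: a number 15.1 percentage points lower from compound 1 to compound 2 (beyond the scatter), the same swap of methyl for hydrogen at the same place, on the benzyl ester pair. The other step, a number 9.1 percentage points lower from compound 1 to compound 3 (within the scatter), concerns the ester, not the change at hand, and only tells how compound 3 relates to compound 1. Among the measured compounds shown here, since the one relevant step was a modest fall beyond the scatter, a fall of similar size is expected here, roughly a number 12.8 percentage points lower from compound 3 to compound 4 (beyond the scatter). Compound 4 is therefore estimated at 6%, with a range from 0% to 18%.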

Compound 4, a percentage reported as activity, at one dose (the size of the read-out at that dose, not a potency): 24%
For compound 4 the middle estimate is 18 percentage points below the measured one; measured number outside the range, above it.
By their numbers in this assay, from the lowest: compounds 2, 3, 4 and 1 (each within the scatter of the next, the first and the last beyond it).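

In this assay, the change from hydroxymethyl to 1-hydroxyethyl gives a number 5.2 percentage points higher from compound 3 to compound 4 (within the scatter), so the fall seen with the benzyl esters does not recur with the free acids, and this position has no single reading for this change: the same change on two cores in this assay, a number 15.1 percentage points lower (beyond the scatter) from compound 1 to compound 2 and a number 5.2 percentage points higher (within the scatter) from compound 3 to compound 4, 20.3 percentage points apart, beyond the scatter of two such steps

The second change tells the same story from the other side, as hydrogen in place of benzyl on an oxygen next to a carbonyl group, with the 1-hydroxyethyl group present, gives a number 11.2 percentage points higher from compound 2 to compound 4 (beyond the scatter), whereas the same change with hydroxymethyl stayed within the scatter: the same change on two cores in this assay, a number 9.1 percentage points lower (within the scatter) from compound 1 to compound 3 and a number 11.2 percentage points higher (beyond the scatter) from compound 2 to compound 4, 20.3 percentage points apart, beyond the scatter of two such steps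

Across these four compounds, then, the two changes do not act independently in this assay, since the outcome of each depends on which form the other site takes.

The four compounds do not tell why the two sites depend on each other, and a single dose and a single time leave open whether the same picture would hold under other conditions. As far as these compounds go, it also remains open whether a methyl or ethyl ester would follow the benzyl ester or the free carboxylic acid, and how a longer chain such as 1-hydroxypropyl in place of 1-hydroxyethyl would read on either form.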